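This account rests on a few compounds, and the source may have more. Where it says the series, first, only, none or still open, it means among the compounds named here.

Of the compounds shown here, two have already been tested, and both share the same core. Compound 1 `Fc1ccccc1Cn1nc(-c2ccccn2)c2cccnc21` is the simpler of the two; in a functional assay (aorta) with Oryctolagus cuniculus as the target (on this read-out higher numbers stand for weaker inhibition and lower numbers for stronger inhibition), compound 1 gives 4800 nM. Compound 2 `Nc1nc(-c2nn(Cc3ccccc3F)c3ncccc23)ncc1C1CCCC1` carries an amino-substituted ring bearing a cyclopentyl group in place of the plain pyridine of compound 1, and in this assay compound 2 gives 904000 nM. Among the compounds with values here, of the two numbers known so far, that of compound 2 is the higher one, and the gap to compound 1 lies well beyond the usual scatter of repeated measurements, so compound 2 is clearly the weaker inhibitor of the pair.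

The next compound to be tested is compound 3 `CC(C)S(=O)(=O)c1cnc(-c2nn(Cc3ccccc3F)c3ncccc23)nc1N`. It differs from compound 2 in one place only: isopropylsulfonyl in place of cyclopentyl on an aromatic carbon

Within the data shown here, no measured pair in this set shows a step of this kind, so there is no direct precedent for its effect. The step from compound 2 to compound 3 is estimated at a 3.0-fold lower number from compound 2 to compound 3 (0.48 log units; beyond the scatter), a modest change toward stronger inhibition that may not clearly exceed the scatter. Compound 3 is accordingly expected to give about 300000 nM, with a likely range from 50000 nM to 1500000 nM.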

Compound 3, half-maximal inhibitory concentration: 517000 nM
Compound 3: middle estimate off by 1.7-fold (0.24 log units), on the low side; measured number inside the range.
By their numbers in this assay, from the lowest: compound 1; then compounds 3 and 2 (each within the scatter of the next).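

In this assay, isopropylsulfonyl in place of cyclopentyl on this aromatic carbon, ortho to an amino group, gives a 1.7-fold lower number from compound 2 to compound 3 (0.24 log units; within the scatter), so this read-out does not separate the two compounds. Within the data shown here, the exchange is large on paper: a five-membered carbon ring with no hydrogen-bond acceptors leaves, and an open group with sulfur, two oxygens and 2 hydrogen-bond acceptors enters, yet in this one pair the number stays within the scatter, something the earlier compounds could not show. Nothing measured here gives a reason for this result.

Among these compounds, what a carboxylic acid, a primary amine or a longer alkyl chain on this same carbon would do to the number remains open, as only two groups at this place can be compared so far. From the compounds shown here alone, whether the same exchange would also stay within the scatter on a different core, or with something other than the amino group on the ring, is equally open.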